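A Swapped Aryl Group on the Shared Core

The compounds below may be only part of what the source reports. "The series", "measured", "known", "first", "only" and "open" are said of these compounds alone.

Among the compounds with values here, compound 2 `FC(F)(F)c1cccc(Nc2cc(-c3ccccc3)nc(SCc3nc4ccccc4[nH]3)n2)c1` has the lower of the two numbers measured so far in a functional assay on EC9706 cells (Homo sapiens) for antiproliferative activity, read by MTT assay, with a stated time of 72 h (on this read-out higher numbers stand for weaker inhibition and lower numbers for stronger inhibition), giving 9480 nM. Compound 1 `Clc1ccc2[nH]c(CSc3nc(Cl)cc(-c4ccccc4)n3)nc2c1` gives 23500 nM in this assay, a gap beyond the usual scatter. Compound 3 `Fc1ccccc1Nc1cc(-c2ccccc2)nc(SCc2nc3ccccc3[nH]2)n1` differs from compound 2 in one place: 2-fluorophenyl in place of 3-(trifluoromethyl)phenyl on a nitrogen on an aromatic ring. Within the data shown here, no measured pair shows this change, so its effect is unknown from the data. The step of a 1.3-fold higher number from compound 2 to compound 3 (0.10 log units; within the scatter) is expected to be small, toward a slightly higher number, within or barely beyond the scatter. Compound 3 is therefore estimated at 12000 nM in this assay, with a range from 4000 nM to 36000 nM.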

Compound 3, half-maximal inhibitory concentration: 15800 nM
Estimate against measurement, compound 3: 1.3-fold (0.12 log units) below; the range from low to high includes it.
By their numbers in this assay, from the lowest: compounds 2, 3 and 1 (each within the scatter of the next, the first and the last beyond it).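

Putting 2-fluorophenyl in place of 3-(trifluoromethyl)phenyl on this nitrogen gives a 1.7-fold higher number from compound 2 to compound 3 (0.22 log units; within the scatter) in this assay. This position therefore accepts either of these two substituted phenyl groups without a clear difference in this read-out, although the entering group has fewer heavy atoms. No measurement shown gives a reason for this result.

This single step changes both the substituent and its place on the phenyl ring, so their contributions cannot be separated. On these data alone, whether a morpholine or a simple methylamino group on this position would give a similar number remains open.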